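Aryl groups on the shared core: outlook for compound 4

The source may hold more compounds than are shown below. What is called first, only, known or untested is meant among the compounds shown, and "the series" means these compounds.

Measured so far:
compound 1 `COc1cc(COC(=O)c2ccco2)cc(OC)c1OC` — 10%
compound 2 `COc1cc(COC(=O)c2ccc(-c3ccccc3C(F)(F)F)o2)cc(OC)c1OC` — 54.9%
compound 3 `COc1cc(COC(=O)c2ccc(-c3ccc(Cl)cc3Cl)o2)cc(OC)c1OC` — 38.3%

In an assay on isolated protein for inhibition of high affinity 3',5'-cyclic-AMP phosphodiesterase 7A (Homo sapiens), read by scintillation proximity assay and cAMP accumulation, with a stated time of 20 min, tested at 10 uM (on this read-out lower numbers stand for less inhibition and higher numbers for more inhibition at the one concentration tested (going by the name of the read-out)), compound 1 gives 10%, compound 2 gives 54.9% and compound 3 gives 38.3%. Compound 3 stands second highest of the three: it lies a number 16.6 percentage points lower from compound 2 to compound 3 (beyond the scatter) and a number 28.3 percentage points higher from compound 1 to compound 3 (beyond the scatter), both beyond the scatter.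

Compound 4 `COc1cc(COC(=O)c2ccc(-c3cccc(C(F)(F)F)c3)o2)cc(OC)c1OC` is not yet measured. The change is 3-(trifluoromethyl)phenyl in place of 2,4-dichlorophenyl on an aromatic carbon.

For the measured compounds named here, two steps bear on it. Placing an aryl group on this carbon of the shared core raised inhibition in both cases seen: a number 44.9 percentage points higher from compound 1 to compound 2 (beyond the scatter) and a number 28.3 percentage points higher from compound 1 to compound 3 (beyond the scatter). Swapping one aryl group for another changed the number only modestly: a number 16.6 percentage points lower from compound 2 to compound 3 (beyond the scatter). A further aryl swap is therefore expected to keep compound 4 well above compound 1 and close to compounds 2 and 3, with a number 6.7 percentage points higher from compound 3 to compound 4 (within the scatter) expected to be small, possibly within the scatter. Compound 4 is estimated at 45%, with a range of 25% to 65%.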

Compound 4, a percentage reported as inhibition, at one concentration (the size of the read-out at that concentration, not a potency): 14%
The estimate for compound 4 lay 31 percentage points above the measured number, and the stated range ends above it.
By their numbers in this assay, from the lowest: compounds 1 and 4 (each within the scatter of the next); then compound 3; then compound 2.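

The gain seen with compounds 2 and 3 does not hold for every aryl group at this carbon: in this assay, hydrogen gives way to 3-(trifluoromethyl)phenyl with a number 4 percentage points higher from compound 1 to compound 4 (within the scatter), so compound 4 is the exception to that pattern. The outcome depends strongly on the aryl substitution, since exchanging 2-(trifluoromethyl)phenyl for 3-(trifluoromethyl)phenyl, with the same atoms in the entering and leaving groups, gives a number 40.9 percentage points lower from compound 2 to compound 4 (beyond the scatter), and exchanging 2,4-dichlorophenyl for 3-(trifluoromethyl)phenyl gives a number 24.3 percentage points lower from compound 3 to compound 4 (beyond the scatter). No available evidence accounts for these differences.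

Still open, on these data alone, is how inhibition responds to other groups on this phenyl ring, such as an amine, a carboxylic acid or a methoxy group. The compounds shown also leave open whether a single chlorine would retain any of the inhibition seen with 2,4-dichlorophenyl.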